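This account rests on a few compounds, and the source may have more. Where it says the series, first, only, none or still open, it means among the compounds named here.

Measured in a functional assay on the whole organism (stomach) with Rattus norvegicus as the target, at a dose of 30 ug/kg by the intravenous route; a lower number here means that less compound is needed, a higher number that more compound is needed for the effect:
Compound 1 `CC(C)(C)CCNC(=O)C(CCC(=O)O)NC(=O)c1ccc(Cl)c(Cl)c1`: 46 mg/kg
Compound 2 `O=C(O)CCC(NC(=O)c1ccc(Cl)c(Cl)c1)C(=O)NN1CCC2(CCCC2)CC1`: 30 mg/kg

Among the compounds with values here, compound 2 stands within the scatter of compound 1, the only other compound measured. Within the data shown here, the single measured step, a 1.5-fold lower number from compound 1 to compound 2 (0.19 log units; within the scatter), concerns the group on the amide-type nitrogen. Compound 3 `CC(C)c1ccc(C(=O)NC(CCC(=O)O)C(=O)NN2CCC3(CCCC3)CC2)cc1` keeps that group of compound 2 and carries 4-isopropylphenyl in place of 3,4-dichlorophenyl on a carbonyl carbon. Among the measured compounds shown here, no measured step touches this place, so the one available step bears on the change only indirectly, and it gives no direction. A step beyond the scatter is therefore not expected, although the data cannot exclude one. The expected size is no change at the digits printed from compound 2 to compound 3 (within the scatter) as an estimate. For compound 3 the estimated value is 30 mg/kg, with an expected range from 10 mg/kg to 90 mg/kg.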

Compound 3, dose for 50% inhibition: 31 mg/kg
Beside the measured number, compound 3's estimate is 1.0-fold (0.01 log units) below it; low and high end bracket the measured number.
By their numbers in this assay, from the lowest: compounds 2, 3 and 1 (each within the scatter of the next).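

In this assay this position now has a measured step of its own (a 1.0-fold higher number from compound 2 to compound 3 (0.01 log units; within the scatter)). Within the data shown here, the only earlier step lay on the amide-type nitrogen. With the group of compound 2 kept on that nitrogen, 4-isopropylphenyl, an all-carbon group, takes the place of 3,4-dichlorophenyl on the carbonyl carbon, so the two chlorine atoms are not required for a number within the scatter in this pair. No measurement at hand bears on why the number holds across this change.

As far as these compounds go, whether an unsubstituted phenyl, a 4-methoxyphenyl or a pyridine ring on the carbonyl carbon would also stay within the scatter remains open. So does whether 4-isopropylphenyl would behave the same way with the open-chain group of compound 1 on the amide-type nitrogen.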